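Para-substituent swap on the benzylamine of compound 2

The source may report more compounds than this note shows. Statements on the series, on what has been measured and on what is new or still open speak of the compounds shown alone.

Measured so far:
Compound 1, `C=C1CC[C@@H]2[C@](C)(CNCc3ccc(O)c(O)c3)[C@H](O)CC[C@@]2(C)[C@@H]1/C=C/C1=CCOC1=O`: in a functional assay on BMMC cells (Mus musculus, strain C57BL/6) for inhibition, with stated times of 5 days and 48 h (a lower number here means a stronger inhibitor, a higher number a weaker inhibitor), compound 1 gives 9440 nM.
Compound 2, `C=C1CC[C@@H]2[C@](C)(CNCc3ccc(F)cc3)[C@H](O)CC[C@@]2(C)[C@@H]1/C=C/C1=CCOC1=O`: in this assay compound 2 gives 350 nM.

Compound 2 stands at the lower of the two numbers; the gap between them is a 27-fold lower number from compound 1 to compound 2 (1.43 log units; beyond the scatter), a large step beyond the scatter.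

Compound 3, `C=C1CC[C@@H]2[C@](C)(CNCc3ccc(Br)cc3)[C@H](O)CC[C@@]2(C)[C@@H]1/C=C/C1=CCOC1=O`, is not yet measured. It differs from compound 2 by bromo in place of fluoro on an aromatic carbon. Going by the values given here, no measured step bears directly on a halogen-for-halogen exchange; the only step available is a 27-fold lower number from compound 1 to compound 2 (1.43 log units; beyond the scatter), which concerns a different substituent pattern. For compound 3 the expected step is therefore a 1.1-fold lower number from compound 2 to compound 3 (0.04 log units; within the scatter), no change beyond the scatter in either direction. Compound 3 is estimated at 320 nM, with a range from 110 nM to 950 nM.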

Compound 3, half-maximal inhibitory concentration: 430 nM
For compound 3 the middle estimate is 1.3-fold (0.13 log units) below the measured one; the measured number falls inside the stated range.
By their numbers in this assay, from the lowest: compounds 2 and 3 (each within the scatter of the next); then compound 1.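

In this assay, bromo in place of fluoro on this aromatic carbon, para to a large group, gives a 1.2-fold higher number from compound 2 to compound 3 (0.09 log units; within the scatter) and so leaves the two halogens indistinguishable here. The large gain over the 3,4-dihydroxyphenyl compound is therefore not specific to fluoro, as 4-bromophenyl also gives a 22-fold lower number from compound 1 to compound 3 (1.34 log units; beyond the scatter) in this series. No measurement available here accounts for either the match between the two halogens or the distance of both from compound 1.

It remains open whether a halogen is needed at all, since the compounds shown include neither the unsubstituted phenyl nor a methoxy or nitrile on the same aromatic carbon. Also open, as far as these compounds go, is whether one hydroxy group alone, at either of the two places it occupies in compound 1, would give a number like that of compound 1 or like those of the halogen compounds.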